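Ring-nitrogen substituent: acetyl to aryl sulfonyl

This account rests on a few compounds, and the source may have more. Where it says the series, first, only, none or still open, it means among the compounds named here.

Values in a functional assay on SGC-7901 cells (Homo sapiens) for cytotoxicity, read by MTT assay, with a stated time of 48 h; a lower number here means a stronger inhibitor, a higher number a weaker inhibitor:
Compound 1, `CCN(CC)c1ccc2cc(C(=O)c3ccc(N4CCN(S(=O)(=O)c5ccc([N+](=O)[O-])cc5)CC4)cc3)oc2c1`: 1860 nM
Compound 2, `CCN(CC)c1ccc2cc(C(=O)c3ccc(N4CCN(S(=O)(=O)c5ccc(F)cc5)CC4)cc3)oc2c1`: > 40000 nM, which is a limit of the assay.
Compound 3, `CCN(CC)c1ccc2cc(C(=O)c3ccc(N4CCN(C(C)=O)CC4)cc3)oc2c1`: 25600 nM

Going by the values given here, compound 3 holds the highest number among those given; the one measured neighbour with a number is compound 1, and the gap is a 14-fold higher number from compound 1 to compound 3 (1.14 log units; beyond the scatter). Compound 2 is known only as a limit (the limit of > 40000 nM in this assay, at which 1 of the 3 values shown sits).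

Compound 4 is `CCN(CC)c1ccc2cc(C(=O)c3ccc(N4CCN(S(=O)(=O)c5ccc(C)cc5)CC4)cc3)oc2c1`. Its change from compound 3 is (4-methylphenyl)sulfonyl in place of acetyl on an amine nitrogen in a ring.

Among the compounds with values here, two measured steps bear on this swap, both going from an aryl sulfonyl to acetyl on the same ring nitrogen: a 14-fold higher number from compound 1 to compound 3 (1.14 log units; beyond the scatter) (large) and an at least 1.5-fold lower number from compound 2 to compound 3 (0.19 log units; that floor lies within the scatter) (within the scatter, and resting on a limit). Read in reverse, they point in opposite directions: putting a sulfonyl back can lower the number a great deal or leave it where it is. Within the data shown here, the two sulfonyl analogues themselves differ by an at least 21-fold higher number from compound 1 to compound 2 (1.33 log units; beyond the scatter), so the group on the sulfonyl-bearing ring decides which way the step goes, and a methyl there has no measured precedent.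

The expected step is therefore a 1.7-fold lower number from compound 3 to compound 4 (0.23 log units; within the scatter), with wide uncertainty. Compound 4 is estimated at 15000 nM, between 3000 nM and 40000 nM.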

Compound 4, half-maximal inhibitory concentration: > 40000 nM
Compound 4 gave a limit, no number (the forecaster's own chance of this, stated with the estimate: 25%); middle value at least 2.6-fold (0.42 log units) away from the limit.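

In this assay compound 4 is a limit, > 40000 nM and no number, and the step that joins it to the fluoro analogue, compound 2, cannot be read: the limit of > 40000 nM in this assay, at which 2 of the 4 values shown sit.

Putting (4-methylphenyl)sulfonyl in place of acetyl on the ring nitrogen gives an at least 1.5-fold higher number from compound 3 to compound 4 (0.19 log units; that floor lies within the scatter), so this swap brings no lowering of the number, and an aryl sulfonyl at this position does not by itself reproduce the result of compound 1. Methyl in place of nitro on the aromatic carbon gives an at least 21-fold higher number from compound 1 to compound 4 (1.33 log units; beyond the scatter), which leaves compound 1 as the only one of the three aryl sulfonyl compounds shown with a number in the assay's range, and ties the large step from acetyl to the nitro-bearing sulfonyl group to the nitro group rather than to the sulfonyl alone.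

On these data alone, whether nitro is unique on this ring remains open, as a nitrile, a trifluoromethyl, an amine or a carboxylic acid in its place could each give a number or another limit. Also open, as far as these compounds go, is whether the nitro-bearing ring needs the sulfonyl at all, a question that a 4-nitrobenzoyl group on the same ring nitrogen would address.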